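Methoxy to methyl in the compound 3 series

The compounds below may be only part of what the source reports. "The series", "measured", "known", "first", "only" and "open" are said of these compounds alone.

Values in a functional assay on SK-OV-3 cells (Homo sapiens) for cytotoxicity (on this read-out lower numbers stand for stronger inhibition of growth and higher numbers for weaker inhibition of growth), follow.
Compound 1 `COc1ccc(C2=C(c3ccc(SC)cc3)CC3CCCN3C2=O)cc1Br` gives 3000 nM
Compound 2 `COc1ccc(C2=C(c3ccc(SC)cc3)CC3CCCN3C2=O)cc1C` gives 15000 nM
Compound 3 `COc1ccc(C2=C(c3ccc(SC)cc3)CC3CCCN3C2=O)cc1` gives 3000 nM

Compound 3 shares the lowest number of the three with compound 1, the step of no change at the digits printed from compound 1 to compound 3 (within the scatter) being within the scatter. Compound 2 stands apart, with the step of a 5.0-fold lower number from compound 2 to compound 3 (0.70 log units; beyond the scatter) marking the gap.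

Compound 4 `CSc1ccc(C2=C(c3ccc(C)cc3)C(=O)N3CCCC3C2)cc1` turns 4-methoxyphenyl into 4-methylphenyl, with methyl in place of methoxy on an aromatic carbon, para to a large group. The count methyl in place of methoxy on an aromatic carbon covers the whole change.

Among the compounds with values here, no measured step touches the methoxy, so the evidence is indirect. The nearest guide is the step of a 5.0-fold higher number from compound 1 to compound 2 (0.70 log units; beyond the scatter) at another aromatic carbon, where methyl enters and the number rises modestly. On that basis a small rise is expected in this assay and it may not clear the scatter. The expected step is a 1.7-fold higher number from compound 3 to compound 4 (0.22 log units; within the scatter) on this estimate. Compound 4 is estimated at 5000 nM with 1500 nM to 15000 nM as the expected range.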

Compound 4, concentration for 50% growth inhibition: 9000 nM
The estimate for compound 4 lay 1.8-fold (0.26 log units) below the measured number; the range from low to high includes it.
By their numbers in this assay, from the lowest: compounds 1 and 3 (each within the scatter of the next); then compounds 4 and 2 (each within the scatter of the next).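

In this assay the methoxy on this aromatic carbon, para to a large group, now has a direct step: methyl in its place gives a 3.0-fold higher number from compound 3 to compound 4 (0.48 log units; beyond the scatter), so this exchange is not neutral on the unsubstituted-neighbour compound, unlike the estimate's reading of a rise that might stay in the scatter. The 4-methylphenyl compound also separates from the 3-bromo-4-methoxyphenyl compound, with a 3.0-fold higher number from compound 1 to compound 4 (0.48 log units; beyond the scatter), whereas a 1.7-fold lower number from compound 2 to compound 4 (0.22 log units; within the scatter) leaves 4-methylphenyl and 4-methoxy-3-methylphenyl unresolved. Nothing on hand explains the rise.

Open, from the compounds shown here alone, is how a hydroxyl, an ethoxy or an amine on this same carbon would compare with methoxy. Also open, going by these compounds, is whether methyl in place of methoxy gives a step of like size when bromo is kept on the ring.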